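Replacing the 2-oxopyrrolidin-1-yl group on a saturated ring carbon

The source may report more compounds than this note shows. Statements on the series, on what has been measured and on what is new or still open speak of the compounds shown alone.

Values so far in a functional assay for inhibition, with Sus scrofa as the target; on this read-out lower numbers stand for stronger inhibition and higher numbers for weaker inhibition
- Compound 1 `CC1(C)C=C(n2ccccc2=O)c2cc(C#N)ccc2O1` gives 50 nM
- Compound 2 `CC1(C)Oc2ccc(C#N)cc2[C@@H](N2CCCC2=O)[C@]1(C)O` gives 4000 nM

Of the two numbers, compound 2 has the higher, meaning the weaker inhibition, and its gap to compound 1 lies beyond the scatter. Compound 3 `CC1(C)Oc2ccc(C#N)cc2[C@@H](Oc2ccnc(O)c2)[C@]1(C)O` has not been measured. Its difference from compound 2 lies in one place, (a group of 8 heavy atoms (5 carbon, 1 nitrogen, 2 oxygen; one six-membered aromatic ring with 1 hetero atom) in place of a group of 6 heavy atoms (4 carbon, 1 nitrogen, 1 oxygen; one five-membered non-aromatic ring with 1 hetero atom), on a saturated ring carbon), next to the ring atom that bears a hydroxy group. Within the data shown here, no measured step isolates this change, so any expectation is loose. The only guide is that compound 1 at 50 nM shows far lower numbers occur among these compounds. The estimated step of a 4.0-fold lower number from compound 2 to compound 3 (0.60 log units; beyond the scatter) is expected to be a modest move toward stronger inhibition in this assay and could prove smaller. The expected value for compound 3 is 1000 nM within an estimated range of 150 nM to 6000 nM on this read-out.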

Compound 3, half-maximal inhibitory concentration: 4 nM
Estimate against measurement, compound 3: 250-fold (2.40 log units) above; measured number outside the range, below it.
By their numbers in this assay, from the lowest: compound 3; then compound 1; then compound 2.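

In this assay, the saturated ring carbon next to the ring atom that bears a hydroxy group proves highly sensitive to its substituent: replacing 2-oxopyrrolidin-1-yl with the group containing one six-membered aromatic ring with 1 hetero atom gives a 1000-fold lower number from compound 2 to compound 3 (3.00 log units; beyond the scatter). The rest of the structure is unchanged across this pair, so the weak number of compound 2 does not belong to the shared core as such. This single change moves the read-out by a large step, and the substituent at this carbon is therefore a major determinant of inhibition on this core. Nothing available explains the size of this step.

Which part of the entering group carries the step remains unresolved, as its aromatic ring, nitrogen and two oxygens all enter together. From the compounds shown here alone, how an amine or a longer chain would read at this same carbon is also open.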